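Series notes: propanoyloxy in place of cyano

The source may report more compounds than this note shows. Statements on the series, on what has been measured and on what is new or still open speak of the compounds shown alone.

Three compounds have results in a functional assay on DLD-1 cells (Homo sapiens) for cytotoxicity, with a stated time of 48 h; a higher number here means a weaker inhibitor, a lower number a stronger inhibitor. Compound 1 `COc1cccc2c(=O)cc(/C=C/[S+](C)[O-])oc12` gives 9000 nM. Compound 3 `Cc1c(/C=C/[S+](C)[O-])oc2ccccc2c1=O` gives 7200 nM in this assay. Compound 2 `C[S+]([O-])/C=C/c1cc(=O)c2cc(C#N)ccc2o1` reaches only a limit in this assay, reported as > 10000 nM. Compound 2 therefore sits at the limit of > 10000 nM in this assay, at which 1 of the 3 values shown sits, with no number of its own. Among the measured compounds shown here, no pair among the three differs in a single place, so no measured step exists to lean on. Compound 4 `CCC(=O)Oc1ccc2oc(/C=C/[S+](C)[O-])cc(=O)c2c1` differs from compound 2 by propanoyloxy in place of cyano on an aromatic carbon. For the measured compounds named here, nothing measured bears on this exchange, and all values so far lie in one region of the scale. The expected step is small, within the scatter: an at least 1.1-fold lower number from compound 2 to compound 4 (0.04 log units; that floor lies within the scatter). Compound 4 is estimated near 9000 nM, between 3500 nM and 25000 nM, with a real chance of another limit.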

Compound 4, half-maximal inhibitory concentration: 9000 nM
Compound 4: the middle estimate sits on the measured number at the digits printed; the measured number falls inside the stated range.
By their numbers in this assay, from the lowest: compounds 3, 1 and 4 (each within the scatter of the next). At a limit, above all of these: compound 2.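

In this assay, among the compounds shown here, propanoyloxy in place of cyano on this aromatic carbon gives the first step at this position: an at least 1.1-fold lower number from compound 2 to compound 4 (0.04 log units; that floor lies within the scatter). Compound 2 stands at a limit, > 10000 nM, so only a floor of the step can be read: the limit of > 10000 nM in this assay, at which 1 of the 4 values shown sits. With propanoyloxy, 5 heavy atoms against 2 for cyano, compound 4 gives a number, 9000 nM.

Going by these compounds, the true size of the step stays open. Also open, on these data alone, is whether an amine, a hydroxyl or a longer acyloxy chain on this carbon would move the number beyond the scatter.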